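A few compounds are considered here, and "the series" means these few. Any claim that something is new, unique, unknown or untested is made for them only; others in the source may bear on it.

Measured compounds and their values:
- compound 1, `Cn1ccc2cc(-c3cc4nccc(-c5ccc(F)cc5)n4n3)ccc21`, in a functional assay on B16-F0 cells (Mus musculus) for inhibition, read by CCK-8 assay, with a stated time of 48 h; a higher number here means a weaker inhibitor, a lower number a stronger inhibitor: 4780 nM
- compound 2, `COc1cc(-c2ccnc3cc(-c4ccc5cc[nH]c5c4)nn23)cc(OC)c1OC`, in this assay: 55 nM
- compound 3, `COc1ccc(-c2cc3nccc(-c4cc(OC)c(OC)c(OC)c4)n3n2)cc1[N+](=O)[O-]`, in this assay: only a limit, > 10000 nM

Among the two numbers, compound 2 stands lowest with 55 nM, while compound 1 gives the higher number of 4780 nM, a gap beyond the scatter. Compound 3 reaches only (the limit of > 10000 nM in this assay, at which 1 of the 3 values shown sits), so it contributes a limit rather than a number.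

Compound 4, `COc1cc(-c2ccnc3cc(-c4ccc5cnn(C)c5c4)nn23)cc(OC)c1OC`, has not yet been measured in this assay. It differs from compound 2 in one place:
1-methyl-1H-indazol-6-yl in place of 1H-indol-6-yl on an aromatic carbon

Among the measured compounds shown here, no measured pair shares exactly this change, so its effect cannot be read from a known step. Compound 4 is expected to give a somewhat higher number than compound 2, a step of a 3.3-fold higher number from compound 2 to compound 4 (0.51 log units; beyond the scatter), modest but likely beyond the scatter. The estimate for compound 4 in this assay is 180 nM, with a range from 45 nM to 900 nM.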

Compound 4, half-maximal inhibitory concentration: 1000 nM
For compound 4 the middle estimate is 5.6-fold (0.74 log units) below the measured one, outside the stated range (above it).
By their numbers in this assay, from the lowest: compound 2; then compound 4; then compound 1. At a limit, above all of these: compound 3.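

In this assay, placing 1-methyl-1H-indazol-6-yl in place of 1H-indol-6-yl on this aromatic carbon gives an 18-fold higher number from compound 2 to compound 4 (1.26 log units; beyond the scatter), the first one-place step shown, and it shows that the number at this position depends strongly on which group sits there. The change removes the hydrogen-bond donor, adds a ring nitrogen and adds a methyl group all at once, and this single step cannot separate these parts. Nothing shown bears on why the number rises.

The compounds shown leave open how 1H-indazol-6-yl, which has the second ring nitrogen without the methyl group, would read on the core of compound 2. Also open, from the compounds shown here alone, is how 1-methyl-1H-indol-6-yl, which has the methyl group without the second ring nitrogen, would read on that same core.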